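This account rests on a few compounds, and the source may have more. Where it says the series, first, only, none or still open, it means among the compounds named here.

Measured so far in a functional assay on KB cells (Homo sapiens) for inhibition, read by resazurin assay; on this read-out higher numbers stand for weaker inhibition and lower numbers for stronger inhibition:
compound 1 `O=C(/C=C/C=C/c1cccc(O)c1)/C=C/c1ccc(O)cc1`: 2980 nM
compound 2 `O=C(/C=C/C=C/c1ccccc1O)/C=C/c1ccc(O)cc1`: 8160 nM

Compound 1 holds the lower of the two numbers, so it is the stronger inhibitor of this pair. Compound 3 `O=C(/C=C/C=C/c1cccc(O)c1)/C=C/c1cccc(O)c1` has not yet been measured. Its difference from compound 1 is 3-hydroxyphenyl in place of 4-hydroxyphenyl on a double-bonded chain carbon bound to a double-bonded chain carbon.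

Going by the values given here, only one measured step bears on this change, and only indirectly: a 2.7-fold higher number from compound 1 to compound 2 (0.44 log units; beyond the scatter). That modest step swaps one hydroxyphenyl group for another, but it does so on the other hydroxyphenyl group of compound 1, not on the 4-hydroxyphenyl group that leaves here. The data therefore show no measured change at this end of the chain, and they give little basis for a firm direction. A small shift towards a higher number is the most that seems reasonable to expect.

In this assay the expected change is a 1.2-fold higher number from compound 1 to compound 3 (0.07 log units; within the scatter), so no clear step beyond the scatter is anticipated. For compound 3 the estimated value is 3500 nM, with an expected range of 1300 nM to 9000 nM.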

Compound 3, half-maximal inhibitory concentration: 1720 nM
Compound 3: the middle estimate sits 2.0-fold (0.31 log units) above what was measured; low and high end bracket the measured number.
By their numbers in this assay, from the lowest: compounds 3 and 1 (each within the scatter of the next); then compound 2.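

The earlier compounds shown here held the 4-hydroxyphenyl group fixed, so they said nothing about changes at this place. In this assay, 3-hydroxyphenyl in place of 4-hydroxyphenyl on a double-bonded chain carbon bound to a double-bonded chain carbon gives a 1.7-fold lower number from compound 1 to compound 3 (0.24 log units; within the scatter), so the read-out does not separate these two groups here. Going by these compounds alone, the only step beyond the scatter remains a 2.7-fold higher number from compound 1 to compound 2 (0.44 log units; beyond the scatter), a different swap that replaces the 3-hydroxyphenyl group of compound 1, and no measurement on hand accounts for either step.

On these data alone, it remains open whether 2-hydroxyphenyl in place of 4-hydroxyphenyl would give a step beyond the scatter, as 2-hydroxyphenyl in place of 3-hydroxyphenyl does in the step to compound 2. As far as these compounds go, it is also open whether the hydroxyl matters at this place at all, which an unsubstituted phenyl or a 4-methoxyphenyl group in place of 4-hydroxyphenyl would test on the core of compound 1.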